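Cyano for trifluoromethoxy: cytotoxicity notes before compound 4

A few compounds are considered here, and "the series" means these few. Any claim that something is new, unique, unknown or untested is made for them only; others in the source may bear on it.

Measured compounds:
Compound 1 `c1ccc(-c2nc3ccccn3c2NC2CCNC2)nc1`. In an ADME assay on THP-1 cells (Homo sapiens) for cytotoxicity (on this read-out lower numbers stand for higher toxicity in this test and higher numbers for lower toxicity in this test), compound 1 gives > 50000 nM, a limit of the test.
Compound 2 `c1ccc(CNc2c(-c3ccccn3)nc3ccccn23)cc1`. In this assay compound 2 gives > 50000 nM, again a limit.
Compound 3 `FC(F)(F)Oc1ccc(Nc2c(-c3ccccn3)nc3ccccn23)cc1`. In this assay compound 3 gives > 50000 nM, also a limit.

Compound 3 therefore stands at the ceiling of the numbers shown: no toxicity was reached in the tested range, and it shares that position with the two other compounds, as noted at the limit of > 50000 nM in this assay, at which 3 of the 3 values shown sit. No ordering among the three is readable.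

Compound 4 `N#Cc1ccc(Nc2c(-c3ccccn3)nc3ccccn23)cc1` differs from compound 3 by the exchange (cyano in place of trifluoromethoxy on an aromatic carbon), cyano in place of trifluoromethoxy on the aromatic carbon para to the large group.

For the measured compounds named here, the only measured step, a step that the two limits leave unreadable from compound 1 to compound 2, changes the substituent on the ring nitrogen rather than the aryl substituent, and its size is not readable since both ends are limits. It offers no guide to the present exchange, so the expectation rests on the position of compound 3 alone.

Compound 4 is expected to stay at the limit, with an estimate of 60000 nM, between 30000 nM and 150000 nM. The expected step, a step that the limit leaves unreadable from compound 3 to compound 4, is none beyond the scatter.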

Compound 4, half-maximal cytotoxic concentration: > 50000 nM
Compound 4 was reported as a limit; the forecaster's own chance of this, stated with the estimate: 80%; the middle value is on the limit's open side.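

In this assay compound 4 gives > 50000 nM as a limit. Its steps from compound 1, compound 2 and compound 3 therefore cannot be read, and all four compounds share one position: the limit of > 50000 nM in this assay, at which 4 of the 4 values shown sit.

The compounds shown leave open whether any change on the shared core would bring a readable value in this assay and so separate these compounds.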